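Cytotoxicity notes: aryl replacements on the shared core

This account rests on a few compounds, and the source may have more. Where it says the series, first, only, none or still open, it means among the compounds named here.

Compound 1 `CC(C)Cn1cc(-c2cc(Nc3ccc(OC(F)(F)F)cc3)ncn2)cn1` — > 10000 nM
Compound 2 `NC(=O)c1ccc(-c2cc(Nc3ccc(OC(F)(F)F)cc3)ncn2)cc1` — > 10000 nM

In an ADME assay on BaF3 cells (Mus musculus) for cytotoxicity (on this read-out higher numbers stand for an effect only at larger amounts of compound and lower numbers for an effect already at smaller amounts), compound 1 gives > 10000 nM, a limit of the assay rather than a number. Compound 2 in this assay likewise gives > 10000 nM, again a limit. The step that the two limits leave unreadable from compound 1 to compound 2 therefore cannot be sized; both values sit on (the limit of > 10000 nM in this assay, at which 2 of the 2 values shown sit). Compound 3 `FC(F)(F)Oc1ccc(Nc2cc(-c3ccc4[nH]ccc4c3)ncn2)cc1` carries 1H-indol-5-yl in place of 4-carbamoylphenyl on an aromatic carbon. Among the measured compounds shown here, the only measured step bears on this change solely by showing that both groups tried so far leave the read-out at the limit. No effect beyond the scatter is expected, so compound 3 is estimated at 15000 nM (4000 nM to 50000 nM), most likely reported as a limit. The expected step that the limit leaves unreadable from compound 2 to compound 3 is thus small.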

Compound 3, half-maximal effective concentration: > 10000 nM
Compound 3 was reported as a limit; the forecaster's own chance of this, stated with the estimate: 70%; the middle value is on the limit's open side.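

Among the compounds shown here, no step among compound 1, compound 2 and compound 3 can be read, since all three values are limits: the limit of > 10000 nM in this assay, at which 3 of the 3 values shown sit. Open remains whether, in this assay, any of the three shows an effect at larger amounts, and how the three would then compare.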